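Swapping Chloro for Methyl in Compound 4

The compounds below may be only part of what the source reports. "The series", "measured", "known", "first", "only" and "open" are said of these compounds alone.

Measured in a functional assay on LOX IMVI cells (Homo sapiens) for cytotoxicity, read by MTT assay, with a stated time of 24 h; on this read-out higher numbers stand for weaker inhibition and lower numbers for stronger inhibition:
- compound 1 `COc1cc(-c2nc(-c3ccccc3)[nH]c2-c2ccnc(NCCCNS(=O)(=O)c3ccc(Cl)cc3)n2)ccc1F`: 83100 nM
- compound 2 `COc1cc(-c2nc(-c3ccccc3)[nH]c2-c2ccnc(NCCCNS(=O)(=O)c3ccc(Cl)cc3)n2)ccc1Cl`: 60900 nM
- compound 3 `O=S(=O)(NCCCNc1nccc(-c2[nH]c(-c3ccccc3)nc2-c2ccc(F)c(O)c2)n1)c1ccc(Cl)cc1`: 14200 nM

Compound 3 has the lowest number of the three, as shown by a 5.9-fold lower number from compound 1 to compound 3 (0.77 log units; beyond the scatter) and a 4.3-fold lower number from compound 2 to compound 3 (0.63 log units; beyond the scatter). Both of those steps change a different part of the molecule, so they say little about what comes next.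

Compound 4 `Cc1ccc(S(=O)(=O)NCCCNc2nccc(-c3[nH]c(-c4ccccc4)nc3-c3ccc(F)c(O)c3)n2)cc1` keeps everything in compound 3 except one group, with methyl in place of chloro on an aromatic carbon, para to a large group (methyl in place of chloro on an aromatic carbon).

Going by the values given here, no measured step makes this swap. The closest comparison is a small substituent exchange elsewhere in the molecule, a 1.4-fold lower number from compound 1 to compound 2 (0.13 log units; within the scatter). That is weak evidence, but it gives no reason to expect a step beyond the scatter in this assay, in either direction.

The expected change is a 1.1-fold higher number from compound 3 to compound 4 (0.02 log units; within the scatter).

For compound 4 the estimated value is 15000 nM, with an expected range from 7000 nM to 32000 nM.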

Compound 4, half-maximal inhibitory concentration: 26300 nM
Compound 4: middle estimate off by 1.8-fold (0.24 log units), on the low side; measured number inside the range.
By their numbers in this assay, from the lowest: compounds 3 and 4 (each within the scatter of the next); then compounds 2 and 1 (each within the scatter of the next).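

Going by these compounds alone, compound 4 gives the first direct reading at this spot on the sulfonyl side of the molecule: in this assay, the change from 4-chlorophenyl to 4-methylphenyl gives a 1.9-fold higher number from compound 3 to compound 4 (0.27 log units; within the scatter) and so stays within the usual scatter. The earlier compounds shown here all carried chloro here and could say nothing about this position, whereas this pair shows that methyl and chloro cannot be told apart at it in this cell assay. No measurement shown here bears on what lies behind this result.

One swap between two single-atom groups leaves open whether this position responds to change at all. An amine, a carboxylic acid or a longer chain in the same place could read quite differently, and the compounds shown do not settle that.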